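The source may hold more compounds than are shown below. What is called first, only, known or untested is meant among the compounds shown, and "the series" means these compounds.

Measured in a functional assay on A549 cells (Homo sapiens) for antiproliferative activity, read by MTT assay, with a stated time of 72 h; a higher number here means a weaker inhibitor, a lower number a stronger inhibitor:

compound 1 `O=C1O[C@H]([C@@H](O)Cn2cc(-c3ccc(Br)cc3)nn2)C(OCc2ccccc2)=C1OCc1ccccc1`: 750 nM
compound 2 `Cc1ccc(-c2cn(C[C@H](O)[C@H]3OC(=O)C(OCc4ccccc4)=C3OCc3ccccc3)nn2)cc1`: 8690 nM
compound 3 `C[Si](C)(C)c1cn(C[C@H](O)[C@H]2OC(=O)C(OCc3ccccc3)=C2OCc2ccccc2)nn1`: 19200 nM

Of these three, compound 3 carries the highest number, at 19200 nM, and is therefore the weakest inhibitor. It lies closest to compound 2, with a 2.2-fold higher number from compound 2 to compound 3 (0.34 log units; beyond the scatter), a modest step, and much further from compound 1, with a 26-fold higher number from compound 1 to compound 3 (1.41 log units; beyond the scatter), a large one.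

The next compound is compound 4 `O=C1O[C@H]([C@@H](O)Cn2ccnn2)C(OCc2ccccc2)=C1OCc1ccccc1`, which differs from compound 3 by a hydrogen atom in place of a group of 4 heavy atoms (3 carbon, 1 silicon; no ring), on an aromatic carbon. The change sits on an aromatic carbon of a five-membered aromatic ring with 3 nitrogen. For the measured compounds named here, no measured step places hydrogen there, so the data offer only indirect guidance. The large 12-fold higher number from compound 1 to compound 2 (1.06 log units; beyond the scatter) shows that this position can matter a great deal, yet it concerns a change on an aromatic ring that compound 3 no longer has. The closer guide is the modest 2.2-fold higher number from compound 2 to compound 3 (0.34 log units; beyond the scatter), which suggests that a small further rise in this assay is more likely than a recovery, although a step within the scatter would be no surprise.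

The expected change is a 1.3-fold higher number from compound 3 to compound 4 (0.11 log units; within the scatter). Compound 4 is estimated at 25000 nM, with an expected range from 8000 nM to 70000 nM.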

Compound 4, half-maximal inhibitory concentration: > 100000 nM
Compound 4: a limit, no number; the forecaster's own chance of this, stated with the estimate: 15%; middle value at least 4.0-fold (0.60 log units) from the limit.
By their numbers in this assay, from the lowest: compound 1; then compound 2; then compound 3. At a limit, above all of these: compound 4.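

In this assay compound 4, with hydrogen on this aromatic carbon of the five-membered aromatic ring with 3 nitrogen, gives no number but only a limit of the assay: the limit of > 100000 nM in this assay, at which 1 of the 4 values shown sits.

Hydrogen in place of the silicon-bearing group is an at least 5.2-fold higher number from compound 3 to compound 4 (0.71 log units; beyond the scatter), hydrogen in place of 4-methylphenyl is an at least 11-fold higher number from compound 2 to compound 4 (1.06 log units; beyond the scatter), and hydrogen in place of 4-bromophenyl is an at least 130-fold higher number from compound 1 to compound 4 (2.12 log units; beyond the scatter). For the compounds shown here, the earlier compounds compared only one group on this carbon with another, and each of them gave a measurable number, whereas these steps show that among the four compounds the one with no heavy atom here is the only one that reaches the limit.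

On these data alone, how far compound 4 really lies from the other three stays open, since each of these steps gives only a lower bound. Also open, as far as these compounds go, is whether a small group such as methyl, an amine, a carboxylic acid or a longer chain on this carbon would give a number in this assay nearer to that of compound 3 or to that of compound 1.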